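Hydroxy to fluoro on the benzylidene ring: a cytotoxicity estimate

The compounds below may be only part of what the source reports. "The series", "measured", "known", "first", "only" and "open" are said of these compounds alone.

Compound 1 `COc1ccc(/C=C2\C(=O)N(c3c(Cl)cccc3Cl)c3ccccc32)cc1OC` — in a functional assay on L132 cells (Homo sapiens) for cytotoxicity, read by MTT assay, with a stated time of 72 h (on this read-out higher numbers stand for an effect only at larger amounts of compound and lower numbers for an effect already at smaller amounts), compound 1 gives > 100 ug/mL, a limit of the assay and not a number.
Compound 2 `O=C1/C(=C\c2c(Cl)cccc2Cl)c2ccccc2N1c1c(Cl)cccc1Cl` — in this assay compound 2 gives > 100 ug/mL, again a limit of the assay.
Compound 3 `O=C1/C(=C\c2ccc(O)cc2)c2ccccc2N1c1c(Cl)cccc1Cl` — in this assay compound 3 gives 30 ug/mL.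

Going by the values given here, compound 3 therefore holds the only actual number among the three; the other two values sit at the limit of > 100 ug/mL in this assay, at which 2 of the 3 values shown sit. Among the compounds with values here, one step joins the measured compounds: an at least 3.3-fold lower number from compound 2 to compound 3 (0.52 log units; beyond the scatter), so the 4-hydroxyphenyl analogue is the one that reaches a number at all.

Compound 4 `O=C1/C(=C\c2ccc(F)cc2)c2ccccc2N1c1c(Cl)cccc1Cl` differs from compound 3 by fluoro in place of hydroxy on an aromatic carbon. Within the data shown here, no measured step exchanges hydroxy for fluoro, so the only bearing comes from the step into compound 3, which shows that the 4-hydroxyphenyl group goes with the sole numerical value, while its replacement by a 2,6-dichlorophenyl group returns a limit. Fluoro is neither of these, and the data offer no direct guide. The step into compound 4 is therefore expected to run toward a higher number, roughly a 2.2-fold higher number from compound 3 to compound 4 (0.34 log units; beyond the scatter), with real chance that the assay reports only a limit. Compound 4 is estimated at 65 ug/mL, within 20 ug/mL to 200 ug/mL.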

Compound 4, concentration for half-maximal effect: 13 ug/mL
For compound 4 the middle estimate is 5.0-fold (0.70 log units) above the measured one; measured number outside the range, below it.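

Fluoro in place of hydroxy on an aromatic carbon, para to a large group, does not lose the measured number in this assay: the change gives a 2.3-fold lower number from compound 3 to compound 4 (0.36 log units; beyond the scatter), so a number on this read-out does not depend on hydroxy at this position, and the fluoro that enters counts no hydrogen-bond donor. The 4-fluorophenyl group also separates clearly from the 2,6-dichlorophenyl group, with an at least 7.6-fold lower number from compound 2 to compound 4 (0.88 log units; beyond the scatter), which makes this the second group at this position, after 4-hydroxyphenyl, to give a number. The value of compound 2 is a limit of the assay and not a number, so that step gives only a bound on the size of the change: the limit of > 100 ug/mL in this assay, at which 2 of the 4 values shown sit.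

The compounds shown leave open how the number would move with an amine, a carboxylic acid or a longer chain such as n-butyl at the same ring position, since only hydroxy and fluoro can be compared there. They also leave open what the 2,6-dichlorophenyl group that all four compounds share on the core contributes, as no compound shown replaces it.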